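From 2-methoxyphenyl to 3-methoxyphenyl: what to expect

The compounds below may be only part of what the source reports. "The series", "measured", "known", "first", "only" and "open" are said of these compounds alone.

- Compound 1 `COc1cccc(OS(=O)(=O)c2ccc(N3CCN(C)C3=O)cc2)c1`: 1600 nM
- Compound 2 `CCCN1CCN(c2ccc(S(=O)(=O)Oc3cccc(OC)c3)cc2)C1=O`: 10000 nM
- Compound 3 `CCCCN1CCN(c2ccc(S(=O)(=O)Oc3ccccc3OC)cc2)C1=O`: > 100000 nM

In a functional assay on M21 cells (Homo sapiens) for antiproliferative activity, read by sulforhodamine B assay, with a stated time of 48 h (on this read-out lower numbers stand for stronger inhibition and higher numbers for weaker inhibition), compound 3 gives > 100000 nM, which is a limit and not a number: the limit of > 100000 nM in this assay, at which 1 of the 3 values shown sits.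

Compound 4 `CCCCN1CCN(c2ccc(S(=O)(=O)Oc3cccc(OC)c3)cc2)C1=O` is unmeasured. It differs from compound 3 as follows: 3-methoxyphenyl in place of 2-methoxyphenyl on an oxygen.

For the measured compounds named here, no measured step covers this change. The only one, a 6.3-fold higher number from compound 1 to compound 2 (0.80 log units; beyond the scatter), concerns the chain instead. Still, compound 1 at 1600 nM and compound 2 at 10000 nM both carry 3-methoxyphenyl and give real numbers, so a clearly lower number is expected. The estimated step is an at least 6.6-fold lower number from compound 3 to compound 4 (0.82 log units; beyond the scatter). For compound 4 the estimate is 15000 nM, with an expected range of 4000 nM to 60000 nM.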

Compound 4, half-maximal inhibitory concentration: 30000 nM
The estimate for compound 4 lay 2.0-fold (0.30 log units) below the measured number; the range from low to high includes it.
By their numbers in this assay, from the lowest: compound 1; then compound 2; then compound 4. At a limit, above all of these: compound 3.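

In this assay, placing 3-methoxyphenyl instead of 2-methoxyphenyl on the oxygen gives an at least 3.3-fold lower number from compound 3 to compound 4 (0.52 log units; beyond the scatter), so this change matters when the chain is butyl. From the compounds shown here alone, the true size of the step stays unknown, as compound 3 gives only a limit: the limit of > 100000 nM in this assay, at which 1 of the 4 values shown sits. With 3-methoxyphenyl kept, the number keeps rising as the chain grows, with a 3.0-fold higher number from compound 2 to compound 4 (0.48 log units; beyond the scatter) and, over the whole series, a 19-fold higher number from compound 1 to compound 4 (1.27 log units; beyond the scatter).

Going by these compounds, it remains open whether the same change would matter as much with the methyl or propyl chain. Nor do these compounds show how plain phenyl or 3-ethoxyphenyl would compare on that oxygen.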